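Carboxy in Place of Hydroxy on the Shared Core

The source may hold more compounds than are shown below. What is called first, only, known or untested is meant among the compounds shown, and "the series" means these compounds.

Compound 1 `Cc1ccc2nc(C(=O)Nc3c(F)cc(-c4cccc(F)c4)cc3F)c(C)c(O)c2c1` is the stronger of the two measured compounds in a functional assay on Hep 3B2 cells (Homo sapiens) for antiproliferative activity, read by MTT assay, with a stated time of 24 h, tested at 11.11 ug/mL (a lower number here means a weaker effect, a higher number a stronger effect of the compound at the concentration tested), where compound 1 gives 25.5%. Among the compounds with values here, its only measured neighbour is compound 2 `CCOc1ccc2nc(C(=O)Nc3c(F)cc(-c4cccc(F)c4)cc3F)c(C)c(O)c2c1`, which in this assay gives 2.03%; the step of a number 23.5 percentage points lower from compound 1 to compound 2 (beyond the scatter) is the sole measured change on the shared core.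

Compound 3 `Cc1ccc2nc(C(=O)Nc3c(F)cc(-c4cccc(F)c4)cc3F)c(C)c(C(=O)O)c2c1` differs from compound 1 as follows: carboxy in place of hydroxy on an aromatic carbon. Within the data shown here, no measured step concerns this position or this exchange, so the one measured step, which touches a different substituent and was of modest size, gives no direct guide to the direction of the change. With the hydrogen-bond donor and acceptor count unchanged but a larger group entering, the author expects a modest downward step in this assay, not clearly beyond the scatter.

On that basis compound 3 is estimated at 14% in this assay, within a range from 0% to 32%, which corresponds to an expected step of a number 11.5 percentage points lower from compound 1 to compound 3 (beyond the scatter).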

Compound 3, a percentage reported as inhibition, at one concentration (the size of the read-out at that concentration, not a potency): 35.6%
Compound 3: the middle estimate sits 21.6 percentage points below what was measured, outside the stated range (above it).
By their numbers in this assay, from the lowest: compound 2; then compound 1; then compound 3.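

At the position opposite the ring nitrogen, the shared core now has its first measured exchange: in this assay the change from hydroxy to carboxy gives a number 10.1 percentage points higher from compound 1 to compound 3 (beyond the scatter) and so moves the read-out upward, not downward. The larger carboxy group is therefore compatible with this effect at the single concentration tested, and the read-out does not depend on keeping hydroxy at this place. The only earlier step concerned a different substituent at another place, and no measurement shown here accounts for the rise.

On these data alone, it remains open how an amine, a methyl ester or a primary amide at this same position would read in this assay, and whether a longer chain ending in a carboxylic acid would keep the upward step. Also open, as far as these compounds go, is whether carboxy in place of hydroxy would move the read-out in the same direction on the core of compound 2, and whether the stronger effect would also appear at other concentrations.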